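The compounds below may be only part of what the source reports. "The series", "measured", "known", "first", "only" and "open" are said of these compounds alone.

Measured in a toxicity assay on THP-1 cells (Homo sapiens) for inhibition; a lower number here means that less compound is tolerated, a higher number that more compound is tolerated:
- Compound 1 `COc1ccc(-c2cnc(NC(=O)c3ncc[nH]3)n2C)cc1`: > 100000 nM, a limit
- Compound 2 `CCCC(=O)Nc1ncc(-c2ccc(OC)cc2)n1C`: > 100000 nM, a limit
- Compound 3 `COc1ccc(-c2cnc(NC(=O)c3cnc[nH]3)n2C)cc1`: > 100000 nM, a limit

Compound 3 has no number in this assay, only the limit > 100000 nM. The other two compounds give no number either, as the series shows (the limit of > 100000 nM in this assay, at which 3 of the 3 values shown sit).

The next compound is compound 4 `COc1ccc(-c2cnc(NC(=O)c3ccc(Br)cc3)n2C)cc1`, with 4-bromophenyl in place of 1H-imidazol-5-yl on a carbonyl carbon.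

Among the compounds with values here, three measured steps concern this same carbonyl carbon: a step that the two limits leave unreadable from compound 1 to compound 3, a step that the two limits leave unreadable from compound 2 to compound 3 and a step that the two limits leave unreadable from compound 1 to compound 2. None of them has a readable size, and none involves 4-bromophenyl, so they give no direction for this change. With nothing to size it against, no definite step is expected in this assay, and compound 4 is expected to stay near the same limit, quite possibly reported as a limit too. The expected change is a number no higher from compound 3 to compound 4 (the limit leaves the size open). For compound 4 the estimate is 100000 nM, with an expected range from 30000 nM to 300000 nM.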

Compound 4, half-maximal cytotoxic concentration: > 100000 nM
Compound 4 was reported as a limit (the forecaster's own chance of this, stated with the estimate: 65%); the middle value lies on the limit itself.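

Compound 4 is reported only as a limit, so its steps from compound 1, compound 2 and compound 3 cannot be read in this assay: the limit of > 100000 nM in this assay, at which 4 of the 4 values shown sit.

The compounds shown leave open whether any group on the carbonyl carbon changes the half-maximal cytotoxic concentration at all.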